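A Benzyl Amine Replaces a Hydroxyalkyl Amine

The source may hold more compounds than are shown below. What is called first, only, known or untested is meant among the compounds shown, and "the series" means these compounds.

Within the data shown here, compound 1 `CC(C)c1n[nH]c2c(NCc3ccc(-c4ccccn4)cc3)nc(NCC(C)(C)O)nc12` is one of two compounds measured in a functional assay on K562 cells (Homo sapiens) for cytotoxicity, read by fluorescence, with a stated time of 72 h (on this read-out higher numbers stand for weaker inhibition and lower numbers for stronger inhibition), where compound 1 gives 29 nM. Compound 2 `CC(C)c1n[nH]c2c(NCc3ccc(-c4ccccn4)cc3)nc(N3CCNCC3)nc12`, in this assay, gives 17 nM, so compound 1 has the higher of the two numbers, though the gap is small: a 1.7-fold lower number from compound 1 to compound 2 (0.23 log units; within the scatter). Compound 3 `COc1ccc(CNc2nc(NCc3ccc(-c4ccccn4)cc3)c3[nH]nc(C(C)C)c3n2)cc1` has not yet been measured. It differs from compound 1 at the side chain on the shared core: 4-methoxyphenyl in place of 1-hydroxy-1-methylethyl on a saturated chain carbon bound to a nitrogen on an aromatic ring. Among the measured compounds shown here, only one measured step exists, and it also reshapes the (2-hydroxy-2-methylpropyl)amino group, swapping it for piperazin-1-yl; that step stayed within the scatter. For the measured compounds named here, a change to (4-methoxybenzyl)amino has no direct precedent here, so no step beyond the scatter is expected, with the range kept wide. The expected step is a 1.4-fold higher number from compound 1 to compound 3 (0.14 log units; within the scatter). Compound 3 is therefore estimated to give 40 nM in this assay, between 12 nM and 130 nM.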

Compound 3, half-maximal inhibitory concentration: 3950 nM
Compound 3: the middle estimate sits 99-fold (1.99 log units) below what was measured; measured number above the stated range.
By their numbers in this assay, from the lowest: compounds 2 and 1 (each within the scatter of the next); then compound 3.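

The position on the shared core is far less forgiving than the first two compounds suggested: in this assay, the change to (4-methoxybenzyl)amino is large (a 140-fold higher number from compound 1 to compound 3 (2.13 log units; beyond the scatter)), and it is similarly large when measured against the piperazine (a 230-fold higher number from compound 2 to compound 3 (2.37 log units; beyond the scatter)). So two quite different groups at this position, (2-hydroxy-2-methylpropyl)amino and piperazin-1-yl, sit within the scatter of each other, while the group carrying a six-membered aromatic ring of carbon only and no hydrogen-bond donor falls well outside it. Nothing available explains why this single change costs so much.

The compounds shown cannot separate the contribution of the aromatic ring from that of its methoxy group, or from the loss of the hydroxyl. An unsubstituted benzylamino group, or a simple amine such as cyclohexylamino, would help to tell these apart.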